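Methoxymethyl to hydroxymethyl on the shared core

The source may report more compounds than this note shows. Statements on the series, on what has been measured and on what is new or still open speak of the compounds shown alone.

In a functional assay on SMMC-7721 cells (Homo sapiens) for antiproliferative activity, read by MTT assay, with a stated time of 48 h (on this read-out higher numbers stand for weaker inhibition and lower numbers for stronger inhibition), compound 1 (`COC/C1=C/C[C@](C)(CCC=C(C)C)/C=C/[C@@H](OC(=O)C=C(C)C)[C@](C)(OC)/C=C/C1=O`) gives 9380 nM as its value and compound 2 (`COC/C1=C/C[C@](C)(CCC=C(C)C)/C=C/[C@@H](OC(=O)C=C(C)C)[C@](C)(O)/C=C/C1=O`) gives 11000 nM as its value. Going by the values given here, these are the only two numbers so far and they lie within the scatter of each other, so compound 1 has no separation from its one neighbour.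

Compound 3 (`CO[C@]1(C)/C=C/C(=O)/C(CO)=C\C[C@](C)(CCC=C(C)C)/C=C/[C@H]1OC(=O)C=C(C)C`) keeps the core of compound 1 and differs by hydrogen in place of methyl on an oxygen on a saturated carbon in a single group, which reads methoxymethyl to hydroxymethyl. Among the compounds with values here, the one measured step of this kind is a 1.2-fold higher number from compound 1 to compound 2 (0.07 log units; within the scatter) and it too is hydrogen in place of methyl on an oxygen on a saturated carbon. Within the data shown here, that step falls at a different oxygen, as compound 2 keeps the methoxymethyl group, so no measurement yet covers this oxygen itself. Among the measured compounds shown here, with only that small step as a guide, no change beyond the scatter is expected in this assay for this replacement.

The estimate amounts to a 1.1-fold higher number from compound 1 to compound 3 (0.03 log units; within the scatter) as the expected step. Compound 3 is expected at 10000 nM with an estimated range from 4500 nM to 22000 nM as the likely span.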

Compound 3, half-maximal inhibitory concentration: 15800 nM
Beside the measured number, compound 3's estimate is 1.6-fold (0.20 log units) below it; the measured number falls inside the stated range.
By their numbers in this assay, from the lowest: compounds 1, 2 and 3 (each within the scatter of the next).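

Going by these compounds alone, the methoxymethyl oxygen, which the earlier compounds left uncovered, now has its own measurement in this assay (a 1.7-fold higher number from compound 1 to compound 3 (0.23 log units; within the scatter)), so the replacement of methoxymethyl by hydroxymethyl on the shared core stays within the scatter. Read with the step at the other oxygen (a 1.2-fold higher number from compound 1 to compound 2 (0.07 log units; within the scatter)), hydrogen in place of methyl has now been read at two places on this core, and neither step lies beyond the scatter, so neither methyl is shown to be needed for the activity seen in this assay. Nothing available accounts for the size of either step.

Still open, on these data alone, is whether a larger or different group at this site would also stay within the scatter, for example ethoxymethyl, a longer ether chain, an aminomethyl group with an amine in place of the hydroxyl, or a carboxylic acid. Also open, as far as these compounds go, is how a compound carrying hydroxymethyl and hydroxy together on the shared core would read, since each replacement is seen here only on its own.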